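A few compounds are considered here, and "the series" means these few. Any claim that something is new, unique, unknown or untested is made for them only; others in the source may bear on it.

Measured compounds:

- compound 1, `Cc1cn(Cc2ccc(O)c(C(C)C)c2)c2ccc(OCC(=O)O)cc12`: 0.38 nM
- compound 2, `Cc1cn(Cc2ccc(O)c(C(C)C)c2)c2c(C)cc(OCC(=O)O)cc12`: 0.18 nM

Among the measured compounds shown here, in an assay on HeLa cells for displacement of a labelled ligand from thyroid hormone receptor beta (Homo sapiens) (on this read-out higher numbers stand for weaker inhibition and lower numbers for stronger inhibition), compound 2 gives the lower of the two numbers so far, and its step from compound 1 is a 2.1-fold lower number from compound 1 to compound 2 (0.32 log units; beyond the scatter), a modest step beyond the scatter brought by a methyl in place of hydrogen on an aromatic carbon.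

Compound 3, `Cc1cn(Cc2ccc(O)c(C(C)C)c2)c2c(Cl)cc(OCC(=O)O)cc12`, is the next compound to be measured. It differs from compound 2 by chloro in place of methyl on an aromatic carbon. For the measured compounds named here, only one measured step bears on this position, a 2.1-fold lower number from compound 1 to compound 2 (0.32 log units; beyond the scatter), and it concerns the methyl itself, not an exchange of methyl for chloro; no measured pair shows such an exchange. The change keeps the count of heavy atoms at this position unchanged, so the expected step in this assay from compound 2 to compound 3 is none beyond the scatter, with a slight lean to a higher number if the methyl contribution is lost. For compound 3 the estimate is 0.25 nM, between 0.09 nM and 0.7 nM, which is expected to mean a step of a 1.4-fold higher number from compound 2 to compound 3 (0.14 log units; within the scatter).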

Compound 3, inhibition constant: 0.09 nM
Compound 3: middle estimate off by 2.8-fold (0.44 log units), on the high side, within the range that was stated.
By their numbers in this assay, from the lowest: compounds 3 and 2 (each within the scatter of the next); then compound 1.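

In this assay, the exchange of methyl for chloro on this aromatic carbon, ortho to a fused ring, gives a 2.0-fold lower number from compound 2 to compound 3 (0.30 log units; within the scatter), so this read-out does not separate the two groups. Chloro in place of hydrogen on the same carbon gives a 4.2-fold lower number from compound 1 to compound 3 (0.63 log units; beyond the scatter). A second group of one heavy atom, after the methyl, therefore also stands beyond the scatter from the unsubstituted compound 1, and the gain seen with compound 2 is not confined to methyl. No measurement on hand accounts for this result.

Open, going by these compounds, is whether fluoro, or a larger group such as methoxy, trifluoromethyl or an amine, on this carbon would hold the number at the level of compounds 2 and 3. Also open, on these data alone, is whether the step from hydrogen carries over to other changes on the core, since only this one position varies here.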